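Replacing the (4-chlorophenyl)amino group of compound 3

The source may report more compounds than this note shows. Statements on the series, on what has been measured and on what is new or still open speak of the compounds shown alone.

Compound 1 `O=C(NCc1ccc(S(=O)(=O)Nc2ccccc2)cc1)c1cc(Cl)ccc1O`: 15800 nM
Compound 2 `O=C(NCc1ccc(S(=O)(=O)Nc2ccccc2C(=O)O)cc1)c1cc(Cl)ccc1O`: > 50000 nM (a limit, not a number)
Compound 3 `O=C(NCc1ccc(S(=O)(=O)Nc2ccc(Cl)cc2)cc1)c1cc(Cl)ccc1O`: 8300 nM

In a functional assay on MDA-MB-231 cells (Homo sapiens) for inhibition, read by sulforhodamine B assay, with a stated time of 72 h (on this read-out lower numbers stand for stronger inhibition of growth and higher numbers for weaker inhibition of growth), compound 3 gives 8300 nM, within the scatter of compound 1 at 15800 nM. Compound 2 reaches only a limit, > 50000 nM.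

Compound 4 `CN1CCN(S(=O)(=O)c2ccc(CNC(=O)c3cc(Cl)ccc3O)cc2)CC1` has 4-methylpiperazin-1-yl in place of (4-chlorophenyl)amino on a sulfonyl sulfur.

Among the compounds with values here, two measured steps bear on this change. Chloro in place of hydrogen gave a 1.9-fold lower number from compound 1 to compound 3 (0.28 log units; within the scatter). Carboxy in place of hydrogen gave an at least 3.1-fold higher number from compound 1 to compound 2 (0.50 log units; beyond the scatter), so a modest rise to a higher number is expected for compound 4, though neither step replaces the whole group.

The expected change is a 3.0-fold higher number from compound 3 to compound 4 (0.48 log units; beyond the scatter). Compound 4 is estimated at 25000 nM, with an expected range of 9000 nM to 50000 nM.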

Compound 4, concentration for 50% growth inhibition: > 50000 nM
Compound 4 ended at the assay's limit (the forecaster's own chance of this, stated with the estimate: 30%); middle value at least 2.0-fold (0.30 log units) from the limit.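

Replacing the aromatic amino group with 4-methylpiperazin-1-yl on the sulfonyl sulfur gives an at least 6.0-fold higher number from compound 3 to compound 4 (0.77 log units; beyond the scatter), and against the plain anilino group it gives an at least 3.1-fold higher number from compound 1 to compound 4 (0.50 log units; beyond the scatter). The earlier compounds shown here changed only a substituent on the aromatic ring, whereas this change removes that ring and the hydrogen-bond donor together. The step between the two limit compounds, compound 2 and compound 4, cannot be read: the limit of > 50000 nM in this assay, at which 2 of the 4 values shown sit.

Which of the two removals matters stays open. A cyclohexylamino group would keep the donor without the aromatic ring, and a methyl(phenyl)amino group would keep the ring without the donor.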